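Aryl tail variation: expected value of the methoxyphenyl analogue

The compounds below may be only part of what the source reports. "The series", "measured", "known", "first", "only" and "open" are said of these compounds alone.

Values in an in vitro assay on CHO-KI cells for displacement of a labelled ligand from thromboxane A2 receptor (Homo sapiens); on this read-out lower numbers stand for stronger inhibition and higher numbers for weaker inhibition:
compound 1 `O=C(O)CCCCCC[C@@H]1[C@@H](CC[C@@H](O)CCc2cccc(F)c2)[C@H](O)C[C@@H]1O`: > 10000 nM, a limit of the assay rather than a number
compound 2 `O=C(O)CCCCCC[C@@H]1[C@@H](CC[C@@H](O)CCc2ccc(F)cc2)[C@H](O)C[C@@H]1O`: > 10000 nM, a limit of the assay rather than a number
compound 3 `Cc1ccccc1CC[C@H](O)CC[C@@H]1[C@@H](CCCCCCC(=O)O)[C@@H](O)C[C@H]1O`: > 10000 nM, a limit of the assay rather than a number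

Compound 3 thus stands at the limit, as do the other two: the limit of > 10000 nM in this assay, at which 3 of the 3 values shown sit. The steps a step that the two limits leave unreadable from compound 1 to compound 2, a step that the two limits leave unreadable from compound 1 to compound 3 and a step that the two limits leave unreadable from compound 2 to compound 3 carry no readable size, so no change of the aryl group so far has moved a value off the limit. Compound 4 `COc1ccc(CC[C@H](O)CC[C@@H]2[C@@H](CCCCCCC(=O)O)[C@@H](O)C[C@H]2O)cc1` differs from compound 3 by 4-methoxyphenyl in place of 2-methylphenyl on a saturated chain carbon, three bonds along the chain from an oxygen on a saturated carbon. Every measured step that bears on this position is unreadable, and nothing among the three compounds points to a gain in this assay. Compound 4 is therefore expected at 10000 nM, with a range of 3000 nM to 30000 nM. The estimated step is then a number no higher from compound 3 to compound 4 (the limit leaves the size open), most likely reported again only as a limit.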

Compound 4, half-maximal inhibitory concentration: > 10000 nM
Compound 4 was reported as a limit; the forecaster's own chance of this, stated with the estimate: 75%; the middle value sits exactly at the limit.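

No step from compound 1, compound 2 or compound 3 to compound 4 can be read, as each value is a limit and not a number: the limit of > 10000 nM in this assay, at which 4 of the 4 values shown sit.

The compounds shown leave open whether any aryl group moves a value off this limit in this assay.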